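The compounds below may be only part of what the source reports. "The series", "measured", "known", "first", "only" and "open" are said of these compounds alone.

Measured so far:
compound 1 `C=C(Br)C(=O)Nc1cccc(-c2cn3nc(-c4ccc(F)cc4)sc3n2)c1`, 610 nM
compound 2 `C=C(Br)C(=O)Nc1cccc(-c2cn3nc(Cc4cccc(OC)c4)sc3n2)c1`, 1100 nM
compound 3 `COc1ccc(-c2nn3cc(-c4cccc(N)c4)nc3s2)cc1`, 74000 nM

In a functional assay on FM3A cells (Mus musculus) for inhibition, read by cell counting, with a stated time of 2 days (on this read-out lower numbers stand for stronger inhibition and higher numbers for weaker inhibition), compound 3 gives the highest number of the three, 74000 nM; the two compounds that carry the (1-bromoethenyl)carbonyl group on the ring nitrogen lie far lower, compound 1 at 610 nM and compound 2 at 1100 nM. Compound 4 `C=C(Br)C(=O)Nc1cccc(-c2cn3nc(-c4ccc(OC)cc4)sc3n2)c1` differs from compound 3 by (1-bromoethenyl)carbonyl in place of hydrogen on a nitrogen on an aromatic ring. Among the compounds with values here, no measured pair differs in exactly this way. Within the data shown here, the only measured step, a 1.8-fold higher number from compound 1 to compound 2 (0.26 log units; within the scatter), changes the group on the aromatic carbon and stays within the scatter, so the large gap between compound 3 and the other two must rest on the entering group. For compound 4 a step of about a 99-fold lower number from compound 3 to compound 4 (1.99 log units; beyond the scatter) downward is therefore expected. Compound 4 is estimated at 750 nM, range 250 nM to 2200 nM.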

Compound 4, half-maximal inhibitory concentration: 890 nM
The estimate for compound 4 lay 1.2-fold (0.07 log units) below the measured number, within the range that was stated.
By their numbers in this assay, from the lowest: compounds 1, 4 and 2 (each within the scatter of the next); then compound 3.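

Within the data shown here, with the 4-methoxyphenyl group held constant, an 83-fold lower number from compound 3 to compound 4 (1.92 log units; beyond the scatter) in this assay, the first direct reading of amino to ((1-bromoethenyl)carbonyl)amino on the aromatic ring. With that group in place, a 1.2-fold lower number from compound 2 to compound 4 (0.09 log units; within the scatter) and a 1.5-fold higher number from compound 1 to compound 4 (0.16 log units; within the scatter), so 4-methoxyphenyl, 3-methoxybenzyl and 4-fluorophenyl on the aromatic carbon are not told apart. No evidence here bears on the origin of the large step.

Going by these compounds, the large step rests on one pair, so its size with other groups on the aromatic carbon remains unknown. On these data alone, whether it requires the bromine remains open, as an acetyl or unbrominated propenoyl group on the same nitrogen would test.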